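This account rests on a few compounds, and the source may have more. Where it says the series, first, only, none or still open, it means among the compounds named here.

Compound 1 `ClCc1ccc(Cn2cnc3c(Cl)ncnc32)cc1` is recorded in a functional assay on HT-29 cells (Homo sapiens) for cytotoxicity, read by sulforhodamine B assay, with a stated time of 48 h (on this read-out lower numbers stand for stronger inhibition of growth and higher numbers for weaker inhibition of growth), as "not determined" (no result reported). Compound 2 `ClCc1ccccc1Cn1cnc2c(Cl)nc(Cl)nc21` reaches only a limit in this assay, > 100000 nM, so no single number stands for it; the limit line the limit of > 100000 nM in this assay, at which 1 of the 2 values shown sits, marks where it sits. Compound 3 `ClCc1ccccc1Cn1cnc2c(Cl)ncnc21` differs from compound 2 by hydrogen in place of chloro on an aromatic carbon. For the measured compounds named here, no step between measured compounds is available, so the expected step from compound 2 to compound 3 in this assay, a step that the limit leaves unreadable from compound 2 to compound 3, is taken as none beyond the scatter. Compound 3 is therefore expected to give about 150000 nM, within 30000 nM to 600000 nM, with a limit again likely.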

Compound 3, concentration for total growth inhibition: > 100000 nM
Compound 3: a limit, no number; the forecaster's own chance of this, stated with the estimate: 70%; the middle value does not contradict the limit.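

No step can be read from compound 2 to compound 3, because both stop at the same limit and neither gives a number: the limit of > 100000 nM in this assay, at which 2 of the 3 values shown sit. The compounds shown leave open whether hydrogen in place of chloro on an aromatic carbon changes the result in this assay.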